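A few compounds are considered here, and "the series" means these few. Any claim that something is new, unique, unknown or untested is made for them only; others in the source may bear on it.

Four compounds with a shared core are followed here. Compound 1 `Oc1ccc(-c2cc(-c3cccc(Cl)c3)nc(-c3cccs3)c2)cc1` carries a thiophen-2-yl group, compound 2 `Oc1ccc(-c2cc(-c3cccnc3)nc(-c3cccc(Cl)c3)c2)cc1` a pyridin-3-yl group, compound 3 `Oc1ccc(-c2cc(-c3cccnc3)nc(-c3ccccc3Cl)c2)cc1` a pyridin-3-yl group with the chlorine moved on the neighbouring aryl ring, and compound 4 `Oc1ccc(-c2cc(-c3ccccc3)nc(-c3cccc(Cl)c3)c2)cc1` a phenyl group. In a functional assay on T47D cells (Homo sapiens) for cytotoxicity, read by CCK-8 assay and cell counting, with a stated time of 2 days (a higher number here means a weaker inhibitor, a lower number a stronger inhibitor), compound 1 gives 5350 nM. In this assay compound 2 gives 25700 nM. For compound 3 the result in this assay is "not determined" (no result reported). Compound 2 thus holds the higher of the two numbers available, and its nearest neighbour is compound 1, as the step of a 4.8-fold higher number from compound 1 to compound 2 (0.68 log units; beyond the scatter) shows.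

The change now considered is phenyl in place of pyridin-3-yl on an aromatic carbon. Among the compounds with values here, only one measured step bears on it, namely a 4.8-fold higher number from compound 1 to compound 2 (0.68 log units; beyond the scatter), which shows that swapping one aromatic group for another at this place can move the number beyond the scatter. Within the data shown here, no step between phenyl and either of the other groups has been measured, so the size of the effect for compound 4 is uncertain. Given that compound 1 gives 5350 nM while compound 2 gives 25700 nM, a lower number is expected for compound 4, with the step of a 3.2-fold lower number from compound 2 to compound 4 (0.51 log units; beyond the scatter) estimated. Compound 4 is therefore expected to give 8000 nM in this assay, within a range from 3000 nM to 25000 nM.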

Compound 4, half-maximal inhibitory concentration: 4790 nM
Beside the measured number, compound 4's estimate is 1.7-fold (0.22 log units) above it, within the range that was stated.
By their numbers in this assay, from the lowest: compounds 4 and 1 (each within the scatter of the next); then compound 2.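

In this assay the step of a 5.4-fold lower number from compound 2 to compound 4 (0.73 log units; beyond the scatter) isolates a single exchange, a ring nitrogen in pyridin-3-yl against a ring carbon in phenyl, and shows that this alone moves the number beyond the scatter at this place on the shared core. Within the data shown here, the step of a 1.1-fold lower number from compound 1 to compound 4 (0.05 log units; within the scatter) lies within the scatter, so phenyl and thiophen-2-yl cannot be told apart here, and among the three groups compared at this place, pyridin-3-yl in compound 2 alone stands apart, with the highest number, something the single earlier step could not show. Nothing given here accounts for this difference.

As far as these compounds go, compound 3 has no reported result, so what moving the chlorine on the neighbouring aryl ring does alongside the pyridin-3-yl group remains open. Also open is how the number would respond at this place to a group of a different kind, such as an amine, a carboxylic acid or a longer chain, since all three groups shown are aromatic rings.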